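Swapping trifluoromethyl for nitro on the shared core

The source may report more compounds than this note shows. Statements on the series, on what has been measured and on what is new or still open speak of the compounds shown alone.

Of the compounds shown here, three built on the shared core have been measured in a physicochemical assay for solubility, read by LC-MS, in phosphate buffer, measured as thermodynamic solubility, with a stated time of 24 h, at pH 7.4; a lower number here means a less soluble compound, a higher number a more soluble compound. Compound 1 `Cc1c(-c2cnn(C)c2)cnc2[nH]cc(-c3cccc(C#N)c3)c12` gives 600 nM, compound 2 `Cn1cc(-c2cnc3[nH]cc(-c4ccnc(C#N)c4)c3c2)cn1` gives 2000 nM, and compound 3 `Cn1cc(-c2cnc3[nH]cc(-c4cccc(C(F)(F)F)c4)c3c2)cn1` gives 1000 nM. In this assay compound 3 holds the second highest of the three numbers; its nearest neighbour is compound 1, and its furthest is compound 2, yet both of those gaps fall within the scatter of repeated measurements, so the three compounds cannot be ordered with confidence.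

Compound 4 `Cn1cc(-c2cnc3[nH]cc(-c4cccc([N+](=O)[O-])c4)c3c2)cn1` has not been measured. It differs from compound 3 in one place: nitro in place of trifluoromethyl on an aromatic carbon. Going by the values given here, no measured pair in this set shows the same change, so there is no step to lean on. Given that compound 3 gives 1000 nM and that the change is a small one on a six-membered aromatic ring of carbon only, the step from compound 3 to compound 4 is expected to be modest, a 1.3-fold lower number from compound 3 to compound 4 (0.10 log units; within the scatter), not clearly beyond the scatter. Compound 4 is therefore estimated at 800 nM, within a range from 250 nM to 2500 nM.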

Compound 4, solubility: 2000 nM
Compound 4: the middle estimate sits 2.5-fold (0.40 log units) below what was measured; the measured number falls inside the stated range.
By their numbers in this assay, from the lowest: compounds 1, 3, 2 and 4 (each within the scatter of the next, the first and the last beyond it).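

On the six-membered aromatic ring of carbon only, nitro in place of trifluoromethyl gives a 2.0-fold higher number from compound 3 to compound 4 (0.30 log units; within the scatter) in this assay for this pair. Going by these compounds alone, this is the first comparison in the set between compounds that differ in one place, and it shows that at this position, meta to a large group, exchanging these two groups leaves the numbers within the scatter. Nothing measured here bears on why the two groups read as they do.

Compound 3 gives 1000 nM and the compounds shown leave open whether an amine, a carboxylic acid or a methoxy group on the same aromatic carbon would stay within the scatter of compound 3 or step clearly beyond it. They also leave open whether the same exchange would give a similar step on the core of compound 1.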